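Thiazole aryl variation: pyrimidine to pyridine with ethoxy

The source may hold more compounds than are shown below. What is called first, only, known or untested is meant among the compounds shown, and "the series" means these compounds.

Three measured compounds share one core and differ only in the aryl group on the thiazole. Compound 1 `Cc1nc(C)n(CC(=O)N2CCN(c3sc(C(F)(F)F)nc3-c3cnc(OC(C)C)nc3)C[C@H]2C)n1` gives 3.4 nM in a functional assay on CHO-K1 cells for antagonist activity at C-X-C chemokine receptor type 3 (Homo sapiens), read by FLIPR, with a stated time of 10 min; on this read-out higher numbers stand for weaker inhibition and lower numbers for stronger inhibition. Compound 2 `Cc1nc(C)n(CC(=O)N2CCN(c3sc(C(F)(F)F)nc3-c3cnc(OC4CCC4)nc3)C[C@H]2C)n1` gives 4 nM in this assay, and compound 3 `Cc1nc(C)n(CC(=O)N2CCN(c3sc(C(F)(F)F)nc3-c3cnc(N4CCCC4)nc3)C[C@H]2C)n1` gives 3.5 nM. All three sit close together: the steps of a 1.2-fold higher number from compound 1 to compound 2 (0.07 log units; within the scatter), a 1.0-fold higher number from compound 1 to compound 3 (0.01 log units; within the scatter) and a 1.1-fold lower number from compound 2 to compound 3 (0.06 log units; within the scatter) are each within the scatter. Compound 3 therefore stands as the second highest of three numbers, with compound 1 nearest and compound 2 furthest, neither separated from it beyond the scatter.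

Compound 4 `CCOc1ccc(-c2nc(C(F)(F)F)sc2N2CCN(C(=O)Cn3nc(C)nc3C)[C@H](C)C2)cn1` is not yet measured. The change from compound 3 is 6-ethoxypyridin-3-yl in place of 2-(pyrrolidin-1-yl)pyrimidin-5-yl on an aromatic carbon. The measured steps bear on it only in part: they show that exchanging isopropoxy, cyclobutyloxy and pyrrolidin-1-yl on the pyrimidine leaves this assay unmoved, which suggests the substituent at that end is tolerant. Among the measured compounds shown here, none of the measured steps, however, tests the exchange of the six-membered aromatic ring with 2 hetero atoms for one with 1 hetero atom, so that part of the change is untested.

Given the flat response among compounds 1, 2 and 3, the step of a 1.7-fold higher number from compound 3 to compound 4 (0.23 log units; within the scatter) is expected to be small, with some allowance for an unfavourable shift. Compound 4 is estimated at 6 nM, within a range of 2 nM to 20 nM.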

Compound 4, half-maximal inhibitory concentration: 8.8 nM
The estimate for compound 4 lay 1.5-fold (0.17 log units) below the measured number, and the stated range covers the measured number.
By their numbers in this assay, from the lowest: compounds 1, 3 and 2 (each within the scatter of the next); then compound 4.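

Among the compounds shown, the aryl group on the thiazole first moves the number beyond the scatter in this assay with 6-ethoxypyridin-3-yl: a 2.5-fold higher number from compound 3 to compound 4 (0.40 log units; beyond the scatter), a 2.2-fold higher number from compound 2 to compound 4 (0.34 log units; beyond the scatter) and a 2.6-fold higher number from compound 1 to compound 4 (0.41 log units; beyond the scatter), each step modest. The exchanges among isopropoxy, cyclobutyloxy and pyrrolidin-1-yl on the pyrimidine stayed within the scatter, so this position is not indifferent to every aryl change, although compound 4 still gives 8.8 nM in this assay. No supporting data bear on the origin of this shift.

The change replaces the ring and its substituent in a single step, so the compounds shown do not separate the effect of the six-membered aromatic ring with 1 hetero atom from that of the ethoxy group. An ethoxy group on the pyrimidine or a pyrrolidin-1-yl group on the pyridine would divide the step into those two parts, while a carboxylic acid or a longer amine chain at the same end of the ring would show whether the tolerance seen so far extends beyond the present ether and pyrrolidine groups.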